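A few compounds are considered here, and "the series" means these few. Any claim that something is new, unique, unknown or untested is made for them only; others in the source may bear on it.

Measured so far in a functional assay on U-87MG ATCC cells (Homo sapiens) for inhibition; on this read-out lower numbers stand for stronger inhibition and higher numbers for weaker inhibition:

Compound 1 `COc1cc(/C=C/C(=O)c2cccc(NC(=O)c3cc(Cl)cc(Cl)c3)c2)ccc1O` gives > 50 ug/mL, which is a limit of the assay and not a number.
Compound 2 `COc1cc(/C=C/C(=O)c2cccc(NC(=O)c3ccco3)c2)ccc1O` gives 6.65 ug/mL.
Compound 3 `COC(=O)C(=O)Nc1cccc(C(=O)/C=C/c2ccc(O)c(OC)c2)c1` gives 12.2 ug/mL.

Compound 1 therefore stands only at the limit of > 50 ug/mL in this assay, at which 1 of the 3 values shown sits; no number is known for it, and every step away from it can be given only as a lower bound. The step to the unmeasured compound 4 `CCOC(=O)C(=O)Nc1cccc(C(=O)/C=C/c2ccc(O)c(OC)c2)c1` is ethoxycarbonyl in place of 3,5-dichlorophenyl on a carbonyl carbon.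

Two measured steps start from the same compound 1 and replace the same 3,5-dichlorophenyl on the carbonyl carbon: an at least 7.5-fold lower number from compound 1 to compound 2 (0.87 log units; beyond the scatter) and an at least 4.0-fold lower number from compound 1 to compound 3 (0.61 log units; beyond the scatter). Both run in the same direction and both exceed the scatter. Between the two replacing groups there is a 1.8-fold higher number from compound 2 to compound 3 (0.26 log units; within the scatter), so the two carbonyl-substituted analogues are not separated in this assay. Replacing the 3,5-dichlorophenyl with a small, oxygen-bearing group of the kind entering in compound 4 has so far always brought the number down from the limit into the measurable range, and a step of at least that size, toward a lower number, is expected here as well.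

Compound 4 is therefore expected at 12 ug/mL, with a range of 5 ug/mL to 30 ug/mL. This estimate corresponds to an expected step of an at least 4.1-fold lower number from compound 1 to compound 4 (0.61 log units; beyond the scatter).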

Compound 4, half-maximal inhibitory concentration: > 50 ug/mL
Compound 4: only a limit was reported; the forecaster's own chance of this, stated with the estimate: 10%; middle value at least 4.1-fold (0.61 log units) from the limit.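

In this assay, methyl in place of hydrogen on the ester chain, which turns methoxycarbonyl into ethoxycarbonyl, gives an at least 4.0-fold higher number from compound 3 to compound 4 (0.61 log units; beyond the scatter), so a very small change at this position can separate a measurable compound from an unmeasurable one. The other comparison gives an at least 7.5-fold higher number from compound 2 to compound 4 (0.87 log units; beyond the scatter), and compound 4 therefore goes against the earlier reading, drawn from compound 2 and compound 3 alone, that a small oxygen-bearing group in place of 3,5-dichlorophenyl on this carbonyl carbon brings the number down into the measurable range. Compound 4 and compound 1 both stand at a limit of the assay and not at a number, so the step between them cannot be read: the limit of > 50 ug/mL in this assay, at which 2 of the 4 values shown sit.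

As far as these compounds go, two esters give no trend, and it stays open whether the number keeps rising with chain length or whether a propoxycarbonyl group or a longer ester chain on the same carbonyl carbon would also stay at the limit. From the compounds shown here alone, how the free carboxylic acid or a primary amide would read at this place also stays open, and these would show whether the ester itself matters here.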